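A few compounds are considered here, and "the series" means these few. Any claim that something is new, unique, unknown or untested is made for them only; others in the source may bear on it.

In a functional assay on MIA PaCa-2 cells (Homo sapiens) for antiproliferative activity, read by MTT assay, with a stated time of 3 days (a higher number here means a weaker inhibitor, a lower number a stronger inhibitor), compound 1 `Cc1ccc(C#Cc2cn(C/C=C\CN3C(=O)c4ccccc4C3=O)c(=O)[nH]c2=O)cc1` gives > 100000 nM as a limit of the assay and not as a number. For the measured compounds named here, compound 2 `CCCCCC#Cc1cn(C/C=C/CN2C(=O)c3ccccc3C2=O)c(=O)[nH]c1=O` gives 60000 nM as the only actual number so far, so there is no measured step against which to rank it. Compound 3 `CCCCC#Cc1cn(C/C=C/CN2C(=O)c3ccccc3C2=O)c(=O)[nH]c1=O` differs from compound 2 by hydrogen in place of methyl on a saturated chain carbon, four bonds along the chain from a triple-bonded carbon in one place: hydrogen in place of methyl on a saturated chain carbon, four bonds along the chain from a triple-bonded carbon. Going by the values given here, no pair of measured compounds differs in just one place, so the data offer no direct guide to the size of this change. In this assay no step beyond the scatter is expected, in either direction. The expected 1.1-fold higher number from compound 2 to compound 3 (0.03 log units; within the scatter) stays within that scatter. Compound 3 is estimated at 65000 nM with an expected range from 30000 nM to 100000 nM in this measurement.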

Compound 3, half-maximal inhibitory concentration: 77000 nM
Compound 3: the middle estimate sits 1.2-fold (0.07 log units) below what was measured, and the stated range covers the measured number.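

In this assay, for the compounds shown here, this pair gives the first readable step at this position: a 1.3-fold higher number from compound 2 to compound 3 (0.11 log units; within the scatter). Hydrogen in place of methyl on a saturated chain carbon, four bonds along the chain from a triple-bonded carbon, therefore gives no step beyond the scatter, and for this pair the butyl to propyl difference does not separate the two compounds. The pair sits on a part of the scale where the limit of the assay is already in play: the limit of > 100000 nM in this assay, at which 1 of the 3 values shown sits.

The compounds shown leave open whether a much longer chain at this place would give a step beyond the scatter. They also leave open how a chain ending in an amine or a carboxylic acid, in place of the methyl, would read in this assay.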